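The compounds below may be only part of what the source reports. "The series", "measured", "known", "first", "only" and "open" are said of these compounds alone.

Among the compounds with values here, compound 3 `CCC(=O)N1C/C(=C\c2cc(OC)c(OC)c(OC)c2)C(=O)/C(=C/c2cc(OC)c(OC)c(OC)c2)C1` stands lowest of the three numbers so far in a functional assay on NCI-H1975 cells (Homo sapiens) for cytotoxicity, read by MTT assay, with a stated time of 72 h; on this read-out higher numbers stand for weaker inhibition and lower numbers for stronger inhibition: compound 3 gives 1700 nM, whereas compound 1 `CCN1C/C(=C\c2ccc(OC)c(OC)c2)C(=O)/C(=C/c2ccc(OC)c(OC)c2)C1` gives 8500 nM and compound 2 `CCCN1C/C(=C\c2ccc(OC)c(OC)c2)C(=O)/C(=C/c2ccc(OC)c(OC)c2)C1` gives 11200 nM. Compound 4 `CCN1C/C(=C\c2cc(OC)c(OC)c(OC)c2)C(=O)/C(=C/c2cc(OC)c(OC)c(OC)c2)C1` is the next compound to be measured; it differs from compound 3 in one place, (ethyl in place of propanoyl on an amine nitrogen in a ring).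

Within the data shown here, only one measured step touches the substituent on the ring nitrogen, and it compares two alkyl groups rather than an alkyl with an acyl: a 1.3-fold higher number from compound 1 to compound 2 (0.12 log units; within the scatter). Among the measured compounds shown here, no measured pair separates the effect of the group on the ring nitrogen from the change in the methoxy pattern on the arms, since compound 3 and compound 1 differ in both places at once. The evidence for the step from compound 3 to compound 4 is therefore thin. Compound 4 is expected to land near compound 3 or somewhat higher, with the step of a 1.8-fold higher number from compound 3 to compound 4 (0.25 log units; within the scatter) taken as uncertain in both size and direction. On that basis compound 4 is estimated at 3000 nM, with a range from 800 nM to 12000 nM in this assay.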

Compound 4, half-maximal inhibitory concentration: 6500 nM
Estimate against measurement, compound 4: 2.2-fold (0.34 log units) below; the measured number falls inside the stated range.
By their numbers in this assay, from the lowest: compound 3; then compounds 4, 1 and 2 (each within the scatter of the next).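

With the arms held the same, ethyl in place of propanoyl on an amine nitrogen in a ring gives a 3.8-fold higher number from compound 3 to compound 4 (0.58 log units; beyond the scatter) in this assay, so this position does respond to the group it carries. Within the data shown here, the only earlier step at this nitrogen compared two alkyl groups and gave a 1.3-fold higher number from compound 1 to compound 2 (0.12 log units; within the scatter), whereas the new step, which exchanges an acyl group for an alkyl group, goes beyond the scatter; this rests on a single pair of compounds and is not yet a pattern. Nothing measured on these compounds accounts for the difference, and the cause of the step remains unexplained.

The compounds shown leave open whether the step follows the carbonyl of propanoyl or the larger size of that group, a question that a propyl group on the same arms, set against compound 3, could separate. Also open, from the compounds shown here alone, is how acetyl or a longer acyl chain such as butanoyl on this nitrogen would compare with propanoyl, and how far any such step holds when the methoxy pattern on the arms changes.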